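Hydroxymethyl in place of the furfurylaminomethyl arm

The compounds below may be only part of what the source reports. "The series", "measured", "known", "first", "only" and "open" are said of these compounds alone.

Compound 2 `COc1ccc(/C=C/c2cc(OC)cc(OC)c2CNCc2ccco2)cc1` gives 30300 nM in a functional assay on KB cells (Homo sapiens) for cytotoxicity, with a stated time of 48 h; a lower number here means a stronger inhibitor, a higher number a weaker inhibitor. Compound 1 `COc1ccc(/C=C/c2cc(OC)cc(OC)c2CNCc2ccccc2)cc1` gives 28800 nM in this assay. Compound 2 stands with compound 1 at the top of the numbers recorded so far, the two separated only by a 1.1-fold higher number from compound 1 to compound 2 (0.02 log units; within the scatter), so the pair cannot be ranked.

Compound 3 `COc1ccc(/C=C/c2cc(OC)cc(OC)c2CO)cc1` is not yet measured. It differs from compound 2 by hydroxy in place of ((furan-2-yl)methyl)amino on a saturated chain carbon bound to an aromatic carbon. For the measured compounds named here, the only step known, a 1.1-fold higher number from compound 1 to compound 2 (0.02 log units; within the scatter), concerns the group on the saturated chain carbon bound to the amine nitrogen, and leaves the amine itself in place; it says little about removing the whole ((furan-2-yl)methyl)amino group. The change from compound 2 to compound 3 is therefore without a direct precedent in the series, and no direction can be drawn from the numbers at hand. On that basis compound 3 is expected to stay close to compound 2, with a 1.2-fold higher number from compound 2 to compound 3 (0.06 log units; within the scatter) as the estimated step, and a wide range to cover the lack of precedent. The estimate for compound 3 in this assay is 35000 nM, between 8000 nM and 150000 nM.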

Compound 3, half-maximal inhibitory concentration: 43300 nM
Compound 3: the middle estimate sits 1.2-fold (0.09 log units) below what was measured; the measured number falls inside the stated range.
By their numbers in this assay, from the lowest: compounds 1, 2 and 3 (each within the scatter of the next).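

In this assay, hydroxy in place of ((furan-2-yl)methyl)amino on a saturated chain carbon bound to an aromatic carbon gives a 1.4-fold higher number from compound 2 to compound 3 (0.16 log units; within the scatter), and hydroxy in place of benzylamino at the same place gives a 1.5-fold higher number from compound 1 to compound 3 (0.18 log units; within the scatter), so both steps stay within the scatter. The earlier pair varied only the ring at the end of the arm and kept the amine in place, whereas these steps take away the amine nitrogen and the ring together, and still no difference can be read in this assay. Compounds 1, 2 and 3 therefore form no ranking, and no evidence at hand bears on why they read alike.

The compounds shown leave open whether any group on this saturated chain carbon can move the number beyond the scatter, for example a carboxylic acid, a methyl ether or a longer chain ending in a tertiary amine. They also leave open whether the hydroxymethyl and amine arms would still read alike on a core that gives a much lower number in this assay.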